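From a bare ring carbon to a butylamino group

A few compounds are considered here, and "the series" means these few. Any claim that something is new, unique, unknown or untested is made for them only; others in the source may bear on it.

Measured in a functional assay on NCI-H460 cells (Homo sapiens) for cytotoxicity, read by MTT assay, with a stated time of 72 h; on this read-out higher numbers stand for weaker inhibition and lower numbers for stronger inhibition:
compound 1 `CCCCCCCCNC1=CC(=O)C=C(C[C@]2(C)[C@@H](C)CC[C@]3(C)C(C)=CCC[C@@H]23)C1=O`: 35000 nM
compound 2 `CC1=CCC[C@H]2[C@](C)(CC3=CC(=O)C=CC3=O)[C@@H](C)CC[C@]12C`: 24000 nM

Only these two numbers exist so far. Compound 2 gives 24000 nM, and that figure lies within the ordinary scatter of repeat measurements of compound 1, so the two cannot be ranked. The unmeasured compound 3 `CCCCNC1=CC(=O)C=C(C[C@]2(C)[C@@H](C)CC[C@]3(C)C(C)=CCC[C@@H]23)C1=O` carries butylamino in place of hydrogen on a double-bonded ring carbon. Among the measured compounds shown here, one measured step bears on this change: a 1.5-fold lower number from compound 1 to compound 2 (0.16 log units; within the scatter). It is the same kind of swap in reverse, with octylamino leaving and hydrogen taking its place. Butylamino is a different group, so this single step is only a thin guide. In this assay no change beyond the scatter is therefore expected, and neither direction is favoured. The expected step is a 1.2-fold higher number from compound 2 to compound 3 (0.07 log units; within the scatter). For compound 3 the estimate is 28000 nM, with an expected range from 12000 nM to 60000 nM.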

Compound 3, half-maximal inhibitory concentration: 6000 nM
For compound 3 the middle estimate is 4.7-fold (0.67 log units) above the measured one; the measured number lies below the stated range.
By their numbers in this assay, from the lowest: compound 3; then compounds 2 and 1 (each within the scatter of the next).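

In this assay, this ring carbon proves sensitive to what it carries, since adding butylamino gives a 4.0-fold lower number from compound 2 to compound 3 (0.60 log units; beyond the scatter), while octylamino at the same place could not be told apart from hydrogen. The length of the chain on the nitrogen therefore counts, as the shorter chain gives a 5.8-fold lower number from compound 1 to compound 3 (0.77 log units; beyond the scatter), so among these three compounds the result depends on the particular chain and not simply on an amino group being present. Nothing available here accounts for this difference.

Going by these compounds, it remains open how a chain of intermediate length such as hexylamino, or a shorter one such as methylamino, would behave at this ring carbon. A ring amine such as morpholine, or a chain ending in a carboxylic acid, is equally uncharted here.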